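The compounds below may be only part of what the source reports. "The series", "measured", "known", "first", "only" and "open" are said of these compounds alone.

Compound 1 `CC(C)(C)OC(=O)/C=C/c1ccc(CN(C(=O)C2CCCCC2)c2cccc(/C=C/C(N)=O)c2)cc1`: in an assay on isolated protein with Bile acid receptor (Homo sapiens) as the target (on this read-out higher numbers stand for an effect only at larger amounts of compound and lower numbers for an effect already at smaller amounts), compound 1 gives > 1000 nM, a limit of the assay.
Compound 2 `CCOC/C=C/c1cccc(N(Cc2ccc(/C=C/C(=O)OC(C)(C)C)cc2)C(=O)C2CCCCC2)c1`: compound 2 gives 220 nM.
Compound 3 `CCOC/C=C/c1ccc(CN(C(=O)C2CCCCC2)c2cccc(/C=C/C(=O)OC)c2)cc1`: compound 3 gives 198000 nM.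

Compound 2 holds the lowest of the two numbers shown; compound 3 lies far above it, beyond the scatter, and the remaining value is the limit of compound 1.

Compound 4 `CC(C)(C)OC(=O)/C=C/c1ccc(CN(C(=O)C2CCCCC2)c2cccc(/C=C/C(=O)OC(C)(C)C)c2)cc1` differs from compound 2 by tert-butoxycarbonyl in place of ethoxymethyl on a double-bonded chain carbon bound to a double-bonded chain carbon. Among the measured compounds shown here, one measured step touches the same place: an at least 4.5-fold lower number from compound 1 to compound 2 (0.65 log units; beyond the scatter), where an ester-free carbonyl group gave way to ethoxymethyl and the number fell, compound 1 sitting at the limit of > 1000 nM in this assay, at which 1 of the 3 values shown sits. Moving back from ethoxymethyl to a carbonyl-bearing group is therefore expected to raise the number, estimated as a 3.2-fold higher number from compound 2 to compound 4 (0.50 log units; beyond the scatter). Compound 4 is expected at 700 nM, within 150 nM to 3500 nM.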

Compound 4, half-maximal effective concentration: > 1000 nM
Compound 4: no number, only a limit; the forecaster's own chance of this, stated with the estimate: 35%; at least 1.4-fold (0.15 log units) between middle value and limit.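

At this place, on a double-bonded chain carbon bound to a double-bonded chain carbon, ethoxymethyl now also compares favourably with an ester, not only with carbamoyl: an at least 4.5-fold higher number from compound 2 to compound 4 (0.65 log units; beyond the scatter). In the two compounds shown, a carbonyl attached here goes with the loss of the number of compound 2, whether it carries amino or tert-butoxy. The step between compound 1 and compound 4 cannot be read, as both stand at the same limit: the limit of > 1000 nM in this assay, at which 2 of the 4 values shown sit.

As far as these compounds go, whether a carboxylic acid or a longer ether chain at this place would keep the number of compound 2 stays open. So does the ranking of the amino and tert-butoxy carbonyl groups.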